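The source may report more compounds than this note shows. Statements on the series, on what has been measured and on what is new or still open speak of the compounds shown alone.

Measured so far in an assay on isolated protein for inhibition of Alpha glucosidase (Homo sapiens), with stated times of 5 min and 15 min, tested at 50 uM; on this read-out lower numbers stand for less inhibition and higher numbers for more inhibition at the one concentration tested (going by the name of the read-out):
- compound 1 `O=C1/C(=C/c2ccccc2)CCC/C1=C\c1cccc(Br)c1`: 27.2%
- compound 2 `COc1cccc(/C=C2\CCC/C(=C\c3ccccc3)C2=O)c1OC`: 31.8%

Compound 1 and compound 2 share the same core and differ only in the aryl group on one side. The two numbers in this assay lie within the usual scatter of each other, so compound 1 cannot be said to inhibit less or more than compound 2; what is known is that both sit at modest inhibition at the single concentration tested.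

Compound 3 `O=C1/C(=C/c2ccccc2)CCC/C1=C\c1ccccc1F` is not yet measured. Relative to compound 1 the change is 2-fluorophenyl in place of 3-bromophenyl on a double-bonded chain carbon bound to a double-bonded ring carbon. Among the compounds with values here, no pair of measured compounds shows a halogen swap of this kind, so there is no step in this assay to lean on. The two numbers seen so far suggest the core itself carries most of the read-out. The expected step of a number 0.8 percentage points higher from compound 1 to compound 3 (within the scatter) is therefore none beyond the scatter. Compound 3 is estimated at 28%, with a range from 15% to 42%.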

Compound 3, a percentage reported as inhibition, at one concentration (the size of the read-out at that concentration, not a potency): 43%
Beside the measured number, compound 3's estimate is 15 percentage points below it; measured number outside the range, above it.
By their numbers in this assay, from the lowest: compounds 1 and 2 (each within the scatter of the next); then compound 3.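

In this assay, within the data shown here, the aryl group on a double-bonded chain carbon bound to a double-bonded ring carbon proves able to move the read-out: 2-fluorophenyl in place of 3-bromophenyl gives a number 15.8 percentage points higher from compound 1 to compound 3 (beyond the scatter) and so provides the first step beyond the scatter. The read-out therefore does not rest on the shared core alone, at least for this pair. No data at hand bear on the reason for this step.

Both the halogen and its place on the ring change in this one step, so the compounds shown do not separate the two contributions. Also open, on these data alone, is how this assay responds when this position carries a phenyl ring bearing an amine or a carboxylic acid rather than a halogen.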